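A few compounds are considered here, and "the series" means these few. Any claim that something is new, unique, unknown or untested is made for them only; others in the source may bear on it.

Measured so far in an in vitro assay on cells for inhibition of Amine oxidase [flavin-containing] B (Homo sapiens), read by fluorescence and Amplex Red, with stated times of 30 min and 45 min; a lower number here means a stronger inhibitor, a higher number a weaker inhibitor:
compound 1, `O=C(CCCc1ccccc1)Nc1nc2ccccc2c(=O)s1`: 34.9 nM
compound 2, `O=C(CCCc1ccc(Cl)c(Cl)c1)Nc1nc2ccccc2c(=O)s1`: 3440 nM
compound 3, `O=C(CCc1ccccc1Br)Nc1nc2ccccc2c(=O)s1`: 2.09 nM

Among these three numbers compound 1 stands second highest. Its nearest neighbour is compound 3, reached by a step of a 17-fold lower number from compound 1 to compound 3 (1.22 log units; beyond the scatter); its furthest is compound 2, reached by a step of a 99-fold higher number from compound 1 to compound 2 (1.99 log units; beyond the scatter). Both of these steps alter the aromatic group at the far end of the chain attached to the amide, and both leave the shared core of compound 1 unchanged.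

Compound 4, `O=C(CCCc1ccccc1)Nc1nc2cc(Cl)ccc2c(=O)s1`, is different in kind. Its change is chloro in place of hydrogen on an aromatic carbon, which sits on the fused ring of the core rather than on the chain. Among the compounds with values here, none of the measured steps touches the core, so neither of them bears directly on this change; the large sizes seen for chain changes therefore give no guide here. In the absence of any relevant precedent, the step expected from compound 1 to compound 4 is a 1.0-fold higher number from compound 1 to compound 4 (0.00 log units; within the scatter), that is, none beyond the usual scatter, though with considerable uncertainty. The estimated value for compound 4 in this assay is 35 nM, expected to lie between 8 nM and 150 nM.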

Compound 4, half-maximal inhibitory concentration: 76.4 nM
The estimate for compound 4 lay 2.2-fold (0.34 log units) below the measured number, within the range that was stated.
By their numbers in this assay, from the lowest: compound 3; then compound 1; then compound 4; then compound 2.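

In this assay, within the data shown here, the step of a 2.2-fold higher number from compound 1 to compound 4 (0.34 log units; beyond the scatter) is the first reading of a change on the shared core rather than on the chain. It shows that adding a chloro group at this aromatic carbon, meta to a fused ring and para to a fused ring, gives a weaker inhibitor, though the step is modest, while still beyond the usual scatter. No measurement is available here to explain this shift.

As far as these compounds go, whether other groups at this carbon, such as fluoro, methoxy or an amine, would give a step of similar size and direction stays open. Also open, from the compounds shown here alone, is whether chloro on another carbon of the same aromatic ring, or at this carbon in compound 3 with its 2-bromophenyl group, would behave the same way.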